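The compounds below may be only part of what the source reports. "The series", "measured", "known", "first", "only" and "open" are said of these compounds alone.

Among the measured compounds shown here, compound 2, `COc1cc(-c2nc3cc(/C=C4\SC(=O)N(CC(=O)N5CCCCC5)C4=O)ccc3[nH]2)cc(OC)c1OC`, is the strongest inhibitor among the three compounds measured so far in a functional assay on A549 cells (Homo sapiens) for inhibition, read by MTT assay, with a stated time of 48 h (a higher number here means a weaker inhibitor, a lower number a stronger inhibitor), where compound 2 gives 980 nM. Its closest neighbour is compound 1, `COc1cc(-c2nc3cc(/C=C4\SC(=O)N(CC(=O)N5CCOCC5)C4=O)ccc3[nH]2)cc(OC)c1OC`, which in this assay gives 2930 nM; the difference is a 3.0-fold lower number from compound 1 to compound 2 (0.48 log units; beyond the scatter). Furthest away is compound 3, `COc1cc(OC)c(-c2nc3cc(/C=C4\SC(=O)N(CC(=O)N5CCCCC5)C4=O)ccc3[nH]2)cc1OC`, which in this assay gives 14500 nM, a change of a 15-fold higher number from compound 2 to compound 3 (1.17 log units; beyond the scatter).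

Compound 4, `COc1cc(-c2nc3cc(/C=C4\SC(=O)N(Cc5ccccc5)C4=O)ccc3[nH]2)cc(OC)c1OC`, shares the core of compound 2 but carries a different group on the chain: phenyl in place of (piperidin-1-yl)carbonyl on a saturated chain carbon bound to an amide-type nitrogen in a ring. For the measured compounds named here, of the two measured steps, only the one from compound 1 to compound 2 touches this part of the molecule, and even there the carbonyl and the chain were kept while only the ring on the carbonyl was swapped; that step was modest in size. The step from compound 2 to compound 3 concerns the trimethoxyphenyl, which compound 4 keeps unchanged, so it says little here. Going by the values given here, no measured pair shows the whole piperidinyl carbonyl removed and a phenyl put in its place.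

Among the compounds with values here, with only this weak guide, the expectation for compound 4 is a modest change in this assay, more likely toward a weaker inhibitor than a stronger one, giving a 1.8-fold higher number from compound 2 to compound 4 (0.26 log units; within the scatter). Compound 4 is therefore estimated at 1800 nM, within a range from 500 nM to 6500 nM.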

Compound 4, half-maximal inhibitory concentration: 670 nM
Beside the measured number, compound 4's estimate is 2.7-fold (0.43 log units) above it; the measured number falls inside the stated range.
By their numbers in this assay, from the lowest: compounds 4 and 2 (each within the scatter of the next); then compound 1; then compound 3.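

In this assay, the whole (piperidin-1-yl)carbonyl can be replaced by phenyl on this saturated chain carbon with a 1.5-fold lower number from compound 2 to compound 4 (0.17 log units; within the scatter) as the result, so the two groups cannot be told apart here. The carbonyl on the chain is therefore not required for inhibition at this level, since a six-membered aromatic ring of carbon only, with no hydrogen-bond acceptor, does as well as the piperidine amide, while the same replacement made on the morpholine amide gives a 4.4-fold lower number from compound 1 to compound 4 (0.64 log units; beyond the scatter), which leaves the (morpholin-4-yl)carbonyl of compound 1 as the group that stands apart from the other two at this position. No measurement shown explains why these groups behave as they do.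

The compounds shown leave open whether the phenyl itself can be improved, for instance with a fluorine or a methoxy group on it, or whether a longer chain, such as two carbons in place of one before the phenyl, would be tolerated. They also leave open how an amine or a carboxylic acid would fare at this position, and whether phenyl would hold its level alongside the 2,4,5-trimethoxyphenyl of compound 3.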